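The source may report more compounds than this note shows. Statements on the series, on what has been measured and on what is new or still open speak of the compounds shown alone.

Of the compounds shown here, three have been measured so far in a functional assay on MGC-803 cells (Homo sapiens) for inhibition, read by MTT assay, with a stated time of 48 h; on this read-out higher numbers stand for weaker inhibition and lower numbers for stronger inhibition. For compound 1 `COc1cc(NCc2ccccc2)cc(OC)c1OC`, the assay returned only a limit, > 80000 nM, and not a number. Of the two compounds with actual numbers, compound 3 `CCC/C=C/C(=O)N(Cc1ccc(OC)c(O)c1)c1cc(OC)c(OC)c(OC)c1` gives 70 nM, while compound 2 `C/C=C/C(=O)N(Cc1ccc(OC)c(OC)c1)c1cc(OC)c(OC)c(OC)c1` gives 20100 nM. Compound 2 therefore has the higher number of the pair, meaning the weaker inhibition, and the gap is well beyond the scatter. However, these two compounds differ in more than one place, so their values do not isolate the effect of any single change.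

The next compound, compound 4 `C/C=C/C(=O)N(Cc1ccc(OC)c(C)c1)c1cc(OC)c(OC)c(OC)c1`, has not yet been measured. It differs from compound 2 at one place, with methyl in place of methoxy on an aromatic carbon, ortho to a methoxy group and meta to a large group (methyl in place of methoxy on an aromatic carbon). Going by the values given here, no measured pair in this assay tests this exchange, so the expectation starts from compound 2 at 20100 nM. No shift beyond the scatter is expected, with a slight lean towards weaker inhibition. The estimated change is a 1.2-fold higher number from compound 2 to compound 4 (0.09 log units; within the scatter). The expected value for compound 4 is 25000 nM, within an estimated range of 8000 nM to 70000 nM.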

Compound 4, half-maximal inhibitory concentration: 14500 nM
Estimate against measurement, compound 4: 1.7-fold (0.24 log units) above; low and high end bracket the measured number.
By their numbers in this assay, from the lowest: compound 3; then compounds 4 and 2 (each within the scatter of the next). At a limit, above all of these: compound 1.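

In this assay, methyl in place of methoxy on an aromatic carbon gives a 1.4-fold lower number from compound 2 to compound 4 (0.14 log units; within the scatter). This is the first pair among the compounds shown that differs in one place only, so it is the first direct reading of this position, ortho to a methoxy group and meta to a large group. It shows that this exchange, which removes a hydrogen-bond acceptor and one heavy atom, does not separate the two compounds in this read-out, although nothing among the compounds shown gives a reason for that.

From the compounds shown here alone, compound 3, at 70 nM, differs from compound 2 in more than one place, so it remains open whether the hydroxy group at this position or the longer chain on the carbonyl side would, alone, shift the value in this assay. Going by these compounds, it also remains open how an amine or a chlorine at this same position would read, and whether the methyl and methoxy groups would still match on a core carrying the longer chain.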